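The compounds below may be only part of what the source reports. "The series", "measured", "known", "first", "only" and "open" are said of these compounds alone.

Compound 1, `CC(C)c1ccc(-c2nc(N)c3cc(Cc4ccccc4)sc3n2)o1`, gives 283 nM in a functional assay on CHO-K1 cells for antagonist activity at adenosine receptor A1 (Homo sapiens), read by a beta-galactosidase reporter and cAMP accumulation, with stated times of 15 min and 6 h; a lower number here means a stronger inhibitor, a higher number a weaker inhibitor. Compound 2, `Cc1nc(-c2nc(N)c3cc(Cc4ccccc4)sc3n2)cs1`, gives 263 nM. Compound 3, `COc1cccc(-c2nc(N)c3cc(Cc4ccccc4)sc3n2)c1`, gives 266 nM.

Compound 3 stands second highest of the three numbers; its nearest is compound 2, and the step of a 1.0-fold higher number from compound 2 to compound 3 (0.00 log units; within the scatter) lies within the scatter, as does a 1.1-fold lower number from compound 1 to compound 3 (0.03 log units; within the scatter). Compound 4, `N#Cc1cccc(-c2nc(N)c3cc(Cc4ccccc4)sc3n2)n1`, differs from compound 3 by 6-cyanopyridin-2-yl in place of 3-methoxyphenyl on an aromatic carbon. For the measured compounds named here, the steps that bear on this change all exchange the same aryl group: a 1.1-fold lower number from compound 1 to compound 2 (0.03 log units; within the scatter), a 1.1-fold lower number from compound 1 to compound 3 (0.03 log units; within the scatter) and a 1.0-fold higher number from compound 2 to compound 3 (0.00 log units; within the scatter), each within the scatter. Going by the values given here, no measured step involves a 6-cyanopyridin-2-yl group, so the expectation rests only on these three aryl variants. Compound 4 is therefore expected to give about 280 nM in this assay, with a range from 90 nM to 900 nM. That expectation means a 1.1-fold higher number from compound 3 to compound 4 (0.02 log units; within the scatter), no step beyond the scatter.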

Compound 4, inhibition constant: > 1000 nM
Compound 4 was reported as a limit (the forecaster's own chance of this, stated with the estimate: 5%); middle value at least 3.5-fold (0.55 log units) from the limit.
By their numbers in this assay, from the lowest: compounds 2, 3 and 1 (each within the scatter of the next). At a limit, above all of these: compound 4.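

This position is not indifferent to the aryl group: the three earlier groups gave values within the scatter of one another, whereas 6-cyanopyridin-2-yl brings an at least 3.7-fold higher number from compound 3 to compound 4 (0.57 log units; beyond the scatter), an at least 3.8-fold higher number from compound 2 to compound 4 (0.58 log units; beyond the scatter) and an at least 3.5-fold higher number from compound 1 to compound 4 (0.54 log units; beyond the scatter). The value of compound 4 is a limit: the limit of > 1000 nM in this assay, at which 1 of the 4 values shown sits.

The compounds shown leave open whether the step follows the nitrile or the ring nitrogen, which a 3-cyanophenyl or an unsubstituted pyridin-2-yl group would separate. As far as these compounds go, how far the number of compound 4 lies beyond its limit also remains open.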